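A few compounds are considered here, and "the series" means these few. Any claim that something is new, unique, unknown or untested is made for them only; others in the source may bear on it.

Of the compounds shown here, three sharing one core have been measured in a functional assay on WM 266-4 cells (Homo sapiens) for antiproliferative activity, read by MTT assay, with a stated time of 24 h; on this read-out higher numbers stand for weaker inhibition of growth and lower numbers for stronger inhibition of growth. Compound 1 `COc1ccc(C2=NN(C(=O)c3cccnc3Cl)C(c3ccc(OC)cc3)C2)cc1` gives 4350 nM in this assay. Compound 2 `COc1ccc(C2=NN(C(=O)c3ccc(C)nc3)C(c3ccc(OC)cc3)C2)cc1` carries 6-methylpyridin-3-yl in place of 2-chloropyridin-3-yl on a carbonyl carbon and gives 4930 nM, a step of a 1.1-fold higher number from compound 1 to compound 2 (0.05 log units; within the scatter). Compound 3 `COc1ccc(C2=NN(C(=O)c3cccnc3Cl)C(c3ccc(Br)cc3)C2)cc1` differs from compound 1 in its core by bromo in place of methoxy on an aromatic carbon; in this assay compound 3 gives 3050 nM, a step of a 1.4-fold lower number from compound 1 to compound 3 (0.15 log units; within the scatter). Both steps lie within the usual scatter, so the three numbers cannot be separated from one another.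

Compound 4 `COc1ccc(C2=NN(C(=O)c3ccc(C)nc3)C(c3ccc(Br)cc3)C2)cc1` has not yet been measured. It stands to compound 3 as compound 2 stands to compound 1: the difference is 6-methylpyridin-3-yl in place of 2-chloropyridin-3-yl on a carbonyl carbon, and its surroundings, a carbonyl carbon whose other neighbour is an amide-type nitrogen in a ring, read the same as in the earlier pair, so this is the same change made on the other core. Because the earlier step was a 1.1-fold higher number from compound 1 to compound 2 (0.05 log units; within the scatter), compound 4 is expected to give an estimated step of a 1.1-fold higher number from compound 3 to compound 4 (0.05 log units; within the scatter). On that footing compound 4 is estimated at 3450 nM, with an expected range from 1700 nM to 7000 nM.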

Compound 4, concentration for 50% growth inhibition: 4280 nM
Estimate against measurement, compound 4: 1.2-fold (0.09 log units) below; measured number inside the range.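

In this assay, 6-methylpyridin-3-yl in place of 2-chloropyridin-3-yl on the bromo-bearing core gives a 1.4-fold higher number from compound 3 to compound 4 (0.15 log units; within the scatter), and this step does not differ from the one on the methoxy-bearing core: the same change on two cores in this assay, a 1.1-fold higher number (0.05 log units; within the scatter) from compound 1 to compound 2 and a 1.4-fold higher number (0.15 log units; within the scatter) from compound 3 to compound 4, 1.2-fold (0.09 log units) apart, within the scatter of two such steps. Bromo in place of methoxy, read on the cores carrying 6-methylpyridin-3-yl and 2-chloropyridin-3-yl, likewise gives a 1.2-fold lower number from compound 2 to compound 4 (0.06 log units; within the scatter) and matches the earlier step: the same change on two cores in this assay, a 1.4-fold lower number (0.15 log units; within the scatter) from compound 1 to compound 3 and a 1.2-fold lower number (0.06 log units; within the scatter) from compound 2 to compound 4, 1.2-fold (0.09 log units) apart, within the scatter of two such steps. Both changes thus carry from one core to the other without a detectable difference, but every step lies within the scatter, so this does not show that either change moves growth inhibition at all, and agreement between such small steps is only a weak test of transfer.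

The compounds shown leave open whether a larger step would carry over in the same way. An amine or a carboxylic acid in place of the bromo group, or a longer chain in place of the methyl group, might give a step that can be read beyond the scatter, and that step could then be tested on both cores.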